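Maximal response in the series: a cyclopentyl step

The source may hold more compounds than are shown below. What is called first, only, known or untested is meant among the compounds shown, and "the series" means these compounds.

Measured so far:
compound 1, `COC(=O)c1ccc(OCCCCOc2ccc(C(=O)CC3CCCC3)c(O)c2C)cc1`, gives 12.2% in an assay on HEK293 cells for positive allosteric modulation of metabotropic glutamate receptor 2 (Rattus norvegicus), read by thallium flux, with a stated time of 2.5 min; a lower number here means a smaller maximal response, a higher number a larger maximal response.
compound 2, `CCCC(=O)c1ccc(OCCCCOc2cc(C(=O)O)ccc2OC)c(C)c1O`, gives 82.8% in this assay.

Within the data shown here, compound 2 stands highest of the two numbers in this assay; the only neighbour, compound 1, lies well lower, beyond the scatter. Compound 3, `COc1ccc(C(=O)O)cc1OCCCCOc1ccc(C(=O)CC2CCCC2)c(O)c1C`, has not been measured. From compound 2 it differs by cyclopentyl in place of ethyl on a saturated chain carbon bound to a carbonyl carbon. Among the measured compounds shown here, no single-change step between measured compounds is available; compound 1 shares the cyclopentyl group but differs from compound 3 elsewhere too, so its low value gives only a hint. For compound 3 a moderate drop is expected, a number 27.8 percentage points lower from compound 2 to compound 3 (beyond the scatter), with wide uncertainty. Compound 3 is estimated at 55%, between 20% and 90%.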

Compound 3, largest response reached (reported as percent of maximum), in percent of the reference or control that the assay uses: 91.8%
Estimate against measurement, compound 3: 36.8 percentage points below; the whole stated range lies below it.
By their numbers in this assay, from the lowest: compound 1; then compounds 2 and 3 (each within the scatter of the next).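

In this assay, cyclopentyl in place of ethyl on a saturated chain carbon bound to a carbonyl carbon is tolerated, with a number 9 percentage points higher from compound 2 to compound 3 (within the scatter). With cyclopentyl held fixed, the large gap lies in the other half of the molecule, with a number 79.6 percentage points higher from compound 1 to compound 3 (beyond the scatter) on changing to 5-carboxy-2-methoxyphenyl in place of 4-(methoxycarbonyl)phenyl on an oxygen on a saturated carbon. No measurement is available that explains either step.

Still open, as far as these compounds go, is whether a cyclohexyl ring or an amine at the cyclopentyl place keeps the response. The separate contributions of the carboxylic acid and the methoxy group to the large step also remain unresolved.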